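A few compounds are considered here, and "the series" means these few. Any claim that something is new, unique, unknown or untested is made for them only; others in the source may bear on it.

Compound 1 `Nc1ncnc2c1c(-c1cnc3[nH]ccc3c1)nn2CCCCCCCCC(=O)NO` gives 24700 nM in a functional assay on MCF7 cells (Homo sapiens) for inhibition, read by MTT assay, with a stated time of 72 h; a lower number here means a stronger inhibitor, a higher number a weaker inhibitor. Compound 3 `Nc1ncnc2c1c(-c1cnc3[nH]ccc3c1)nn2CCCCCCC(=O)NO` gives 19800 nM in this assay. Compound 2 `Nc1nc2cc(-c3nn(CCC(=O)NO)c4ncnc(N)c34)ccc2o1` reaches only a limit of this assay, > 100000 nM.

Compounds 3 and 1 share one core, and the step of a 1.2-fold higher number from compound 3 to compound 1 (0.10 log units; within the scatter) comes from 2-(hydroxycarbamoyl)ethyl in place of hydroxycarbamoyl on a saturated chain carbon, six bonds along the chain from an aromatic nitrogen. Compound 4 `Nc1nc2cc(-c3nn(CCCCC(=O)NO)c4ncnc(N)c34)ccc2o1` carries the same kind of change on the core of compound 2, (2-(hydroxycarbamoyl)ethyl in place of hydroxycarbamoyl on a saturated chain carbon, two bonds along the chain from an aromatic nitrogen); the place is not the same, two bonds along the chain from an aromatic nitrogen rather than six. The difference between the two cores is not broken down here. Compound 2 sits at the limit of > 100000 nM in this assay, at which 1 of the 3 values shown sits, so its starting point is known only as a limit. The step from compound 2 to compound 4 is expected to be small, a step that the limit leaves unreadable from compound 2 to compound 4, beside a 1.2-fold higher number from compound 3 to compound 1 (0.10 log units; within the scatter). Compound 4 is therefore estimated at 150000 nM, most likely again only a limit.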

Compound 4, half-maximal inhibitory concentration: 14000 nM
Compound 4: middle estimate off by 11-fold (1.03 log units), on the high side; measured number below the stated range.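

On the core of compound 2, in this assay, putting 2-(hydroxycarbamoyl)ethyl in place of hydroxycarbamoyl gives an at least 7.1-fold lower number from compound 2 to compound 4 (0.85 log units; beyond the scatter). From the compounds shown here alone, the same change therefore does not carry over from one core to the other with the same size: the same change on two cores in this assay, a 1.2-fold higher number (0.10 log units; within the scatter) from compound 3 to compound 1 and an at least 7.1-fold lower number (0.85 log units; beyond the scatter) from compound 2 to compound 4, at least 8.9-fold (0.94 log units) apart, beyond the scatter of two such steps For compound 2 the value > 100000 nM is only a limit, so the full size of this step stays unknown, and the two pairs do not show whether the core or the place of the change sets the gap.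

Going by these compounds, whether a longer chain on the core of compound 2 would lower the number further stays open. So does whether a carboxylic acid in place of the hydroxycarbamoyl end would keep this inhibition.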